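Replacing Phenoxy with 3-Chlorophenyl: An Expected Clearance

This account rests on a few compounds, and the source may have more. Where it says the series, first, only, none or still open, it means among the compounds named here.

Within the data shown here, in an ADME assay on liver (Mesocricetus auratus) for metabolic stability, using microsomes (on this read-out lower numbers stand for slow clearance and higher numbers for fast clearance), compound 1 `N#Cc1ccc(C2CCN(C(=O)Nc3cc(-c4ccccn4)n[nH]3)CC2)cc1` gives 80.8 mL.min-1.g-1 and compound 2 `O=C(Nc1cc(-c2ccccn2)n[nH]1)N1CCC(Oc2ccccc2)CC1` gives 98.5 mL.min-1.g-1 as the only two numbers so far. These values lie within the usual scatter of each other, so compound 2 stands level with compound 1.

Compound 3 `O=C(Nc1cc(-c2ccccn2)n[nH]1)N1CCC(c2cccc(Cl)c2)CC1` has not yet been measured. Its change from compound 2 is 3-chlorophenyl in place of phenoxy on a saturated ring carbon while the shared core stays the same. Among the measured compounds shown here, the one measured step at that ring carbon, phenoxy in place of 4-cyanophenyl, is a 1.2-fold higher number from compound 1 to compound 2 (0.09 log units; within the scatter) and gives no sign of a real difference. Compound 3 resembles compound 1 in carrying a substituted phenyl group at this place, but neither measured compound has the 3-chlorophenyl group, so this single step is thin evidence. No shift beyond the scatter is therefore expected, and the estimated step is a 1.0-fold lower number from compound 2 to compound 3 (0.02 log units; within the scatter) for now. In this assay the estimate for compound 3 is 95 mL.min-1.g-1 with an expected range of 50 mL.min-1.g-1 to 180 mL.min-1.g-1 around it.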

Compound 3, intrinsic clearance in microsomes: 63.5 mL.min-1.g-1
Beside the measured number, compound 3's estimate is 1.5-fold (0.17 log units) above it, within the range that was stated.
By their numbers in this assay, from the lowest: compounds 3, 1 and 2 (each within the scatter of the next).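

In this assay, three different groups have now been compared on the same saturated ring carbon, and every step between them stays within the usual scatter: putting 3-chlorophenyl in place of phenoxy gives a 1.6-fold lower number from compound 2 to compound 3 (0.19 log units; within the scatter), and putting it in place of 4-cyanophenyl gives a 1.3-fold lower number from compound 1 to compound 3 (0.10 log units; within the scatter). This shows that exchanging phenoxy, with its one hydrogen-bond acceptor, for 3-chlorophenyl, with none, brings no step beyond the scatter, so compound 3 reads level with both compound 1 and compound 2. No measurement is available that would explain why these groups read alike.

From the compounds shown here alone, all three groups contain one six-membered aromatic ring of carbon only, so it remains open whether an amine, a carboxylic acid or a longer alkyl chain on this ring carbon would move the number beyond the scatter. It also remains open whether a 4-chlorophenyl or 2-chlorophenyl group would read like 3-chlorophenyl, since only one chlorine-bearing group appears among these compounds.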